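Cyanoguanidine chain variation on a chromanol scaffold

The source may report more compounds than this note shows. Statements on the series, on what has been measured and on what is new or still open speak of the compounds shown alone.

Compound 1 `CC1(C)Oc2ccc(C#N)cc2[C@@H](N2CCCN=C2NC#N)[C@@H]1O` gives 120 nM in a functional assay (thoracic aorta) with Rattus norvegicus as the target; a lower number here means a stronger inhibitor, a higher number a weaker inhibitor.
Compound 2 `C/N=C(\NC#N)N[C@@H]1c2cc(C#N)ccc2OC(C)(C)[C@H]1O` gives 200 nM in this assay.
Compound 3 `CC(C)/N=C(/NC#N)N[C@@H]1c2cc(C#N)ccc2OC(C)(C)[C@H]1O` gives 660 nM in this assay.

Compound 3 stands highest of the three numbers: compound 2 lies nearest and compound 1 furthest, both beyond the scatter. Compound 4 `COCC/N=C(/NC#N)N[C@@H]1c2cc(C#N)ccc2OC(C)(C)[C@H]1O` differs from compound 3 by 2-methoxyethyl in place of isopropyl on a double-bonded nitrogen. Among the measured compounds shown here, the one measured step that bears on this place is a 3.3-fold higher number from compound 2 to compound 3 (0.52 log units; beyond the scatter), where an isopropyl in place of a methyl on the same nitrogen weakened inhibition. For the measured compounds named here, compound 4 carries a longer but unbranched chain, so the data give no direct precedent; the two known substituents on this nitrogen bracket a modest range, and compound 4 is expected to fall within it rather than beyond compound 3. The estimated step is a 1.7-fold lower number from compound 3 to compound 4 (0.22 log units; within the scatter), a small move downward that may not clear the scatter. Compound 4 is therefore expected to give about 400 nM, with a range from 150 nM to 1200 nM.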

Compound 4, half-maximal inhibitory concentration: 1690 nM
For compound 4 the middle estimate is 4.2-fold (0.63 log units) below the measured one, and the stated range ends below it.
By their numbers in this assay, from the lowest: compounds 1 and 2 (each within the scatter of the next); then compound 3; then compound 4.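

In this assay, the 2-methoxyethyl chain on the double-bonded nitrogen gives a further rise (a 2.6-fold higher number from compound 3 to compound 4 (0.41 log units; beyond the scatter)), so the earlier rise (a 3.3-fold higher number from compound 2 to compound 3 (0.52 log units; beyond the scatter)) does not stop at isopropyl. A branch is therefore not needed for a higher number at this place: 2-methoxyethyl has none, yet compound 4 stands highest of the four compounds. The entering chain also brings one hydrogen-bond acceptor where isopropyl has none, but no measurement shown here explains the rise, and the roles of chain length and the oxygen cannot be told apart.

On these data alone, a plain butyl chain on this nitrogen would bear on that question, and how it would compare remains open. As far as these compounds go, it also remains open how a chain ending in a hydroxyl or an amine would behave at this place.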